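From Benzyl(methyl)amino to (2-Cyclohexylethyl)amino at a Limit

The source may hold more compounds than are shown below. What is called first, only, known or untested is meant among the compounds shown, and "the series" means these compounds.

Values measured in an ADME assay on a cell-free system (plasma, Homo sapiens) for metabolic stability, tested at 1 uM (a higher number here means that the compound lasts longer, a lower number that the compound disappears faster), so far
Compound 1 `C=CC(=O)NC1CCN(S(=O)(=O)c2ccc(C(=O)NCc3ccccc3)cc2)CC1` gives > 6 h as a limit
Compound 2 `C=CC(=O)NC1CCN(S(=O)(=O)c2ccc(C(=O)NCCCc3ccccc3)cc2)CC1` gives > 6 h as a limit
Compound 3 `C=CC(=O)NC1CCN(S(=O)(=O)c2ccc(C(=O)N(C)Cc3ccccc3)cc2)CC1` gives > 6 h as a limit

Compound 3 therefore stands at a limit and not at a number, and it holds no rank among the three (the limit of > 6 h in this assay, at which 3 of the 3 values shown sit). The move to compound 4 `C=CC(=O)NC1CCN(S(=O)(=O)c2ccc(C(=O)NCCC3CCCCC3)cc2)CC1` puts (2-cyclohexylethyl)amino in place of benzyl(methyl)amino on a carbonyl carbon. Among the compounds with values here, three measured steps bear on this change, all of them made at that same carbonyl carbon (a step that the two limits leave unreadable from compound 1 to compound 2; a step that the two limits leave unreadable from compound 1 to compound 3; a step that the two limits leave unreadable from compound 2 to compound 3). None of the three has a readable size. Within the data shown here, no measured compound carries a non-aromatic ring in this group, so that part of the change has no step behind it. Compound 2 comes closest, with (3-phenylpropyl)amino and the amide hydrogen that compound 4 also has. Compound 2 gives > 6 h as a limit of this assay again. No step beyond the scatter is expected, in either direction, and compound 4 is expected to read as a limit too. The estimated change is a step that the limit leaves unreadable from compound 3 to compound 4 (no direction expected). For compound 4 the estimated half-life is 8 h (expected range 5 h to 20 h).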

Compound 4, half-life: > 6 h
Compound 4: a limit, no number (the forecaster's own chance of this, stated with the estimate: 85%); the middle value is on the limit's open side.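

In this assay compound 4 gives > 6 h, a limit and not a number. Its steps from compound 1, compound 2 and compound 3 cannot be read: the limit of > 6 h in this assay, at which 4 of the 4 values shown sit.

The compounds shown leave open how far any of the four lasts past that limit, and so whether the changes among them alter the half-life at all.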